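Shifting a chloro group in a weakly cytotoxic series

The source may hold more compounds than are shown below. What is called first, only, known or untested is meant among the compounds shown, and "the series" means these compounds.

Compound 3 `COc1cccc(/C=C/C(=O)c2sc(Nc3cccc(Cl)c3)nc2C)c1` is tested in a functional assay on NCI-H460 cells (Homo sapiens) for cytotoxicity, read by MTT assay; on this read-out lower numbers stand for stronger inhibition and higher numbers for weaker inhibition. In this assay compound 3 gives > 25000 nM, which is a limit of the assay rather than a number. Its companions set the scene: compound 1 `COc1cccc(/C=C/C(=O)c2sc(Nc3ccc(Cl)c(Cl)c3)nc2C)c1` gives 20100 nM in this assay, and the step of an at least 1.2-fold higher number from compound 1 to compound 3 (0.09 log units; that floor lies within the scatter) comes from hydrogen in place of chloro on an aromatic carbon. Compound 2 `Cc1nc(Nc2cccc(Cl)c2)sc1C(=O)/C=C/c1ccc(Cl)cc1` gives > 25000 nM in this assay, likewise a limit. The step that the two limits leave unreadable from compound 2 to compound 3 cannot be sized. Compound 4 `COc1cccc(/C=C/C(=O)c2sc(Nc3ccc(Cl)cc3)nc2C)c1` differs from compound 3 by 4-chlorophenyl in place of 3-chlorophenyl on a nitrogen on an aromatic ring. Among the compounds with values here, no measured step moves a chloro group from one ring position to another, and the only nearby step is within scatter, so the expected outcome is a number no higher from compound 3 to compound 4 (the limit leaves the size open), no step beyond scatter, given (the limit of > 25000 nM in this assay, at which 2 of the 3 values shown sit). Compound 4 is therefore estimated at 25000 nM, within 12000 nM to 60000 nM.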

Compound 4, half-maximal inhibitory concentration: > 25000 nM
Compound 4 gave a limit, no number; the forecaster's own chance of this, stated with the estimate: 65%; the middle value sits exactly at the limit.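

In this assay compound 4 gives > 25000 nM, a limit and not a number, so the shift from 3-chlorophenyl to 4-chlorophenyl cannot be sized, and neither can any other step between two limits: the limit of > 25000 nM in this assay, at which 3 of the 4 values shown sit.

Within the data shown here, the one readable step is an at least 1.2-fold higher number from compound 1 to compound 4 (0.09 log units; that floor lies within the scatter), so its floor shows no firm effect of losing that chloro, though the true size stays open.

As far as these compounds go, whether an amine or a carboxylic acid in place of chloro on this ring would give a measurable number remains open.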